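The source may report more compounds than this note shows. Statements on the series, on what has been measured and on what is new or still open speak of the compounds shown alone.

Measured so far:
compound 1, `O=C(Nc1ccc(-c2cscn2)cc1)[C@@H]1CCCN(Cc2ccc(F)c(F)c2)C1` — 6000 nM
compound 2, `O=C(Nc1ccc(-c2ccncc2)cc1)C1CCCN(Cc2ccc(F)c(F)c2)C1` — 600 nM

In a functional assay on A-375 cells (Homo sapiens) for antiproliferative activity (on this read-out higher numbers stand for weaker inhibition and lower numbers for stronger inhibition), compound 2 gives 600 nM, the lowest of the two numbers recorded; the nearest is compound 1, whose value of 6000 nM lies a step beyond the scatter above it. Compound 3, `O=C(Nc1ccc(-c2ccco2)cc1)C1CCCN(Cc2ccc(F)c(F)c2)C1`, has not yet been measured. Compared with compound 2 it carries furan-2-yl in place of pyridin-4-yl on an aromatic carbon. Among the measured compounds shown here, no measured pair isolates such a change, so the expectation rests on the two values shown and on the nature of the swap. Since compound 1, which also bears a five-membered ring in this place, gives the higher number, compound 3 is expected to move toward weaker inhibition, with a step of a 3.3-fold higher number from compound 2 to compound 3 (0.52 log units; beyond the scatter) that is more likely beyond the scatter than within it. Compound 3 is therefore estimated at 2000 nM, within a range from 500 nM to 8000 nM.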

Compound 3, half-maximal inhibitory concentration: 1040 nM
Beside the measured number, compound 3's estimate is 1.9-fold (0.28 log units) above it; the measured number falls inside the stated range.
By their numbers in this assay, from the lowest: compounds 2 and 3 (each within the scatter of the next); then compound 1.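

In this assay, among the compounds shown here, replacing pyridin-4-yl with furan-2-yl on the aromatic carbon gives a 1.7-fold higher number from compound 2 to compound 3 (0.24 log units; within the scatter), the first single-place comparison at this position. This pair shows that the position accepts a five-membered aromatic ring with an oxygen in place of a six-membered aromatic ring with a nitrogen, with no change beyond the scatter, so the pyridine nitrogen is not needed to keep this level of antiproliferative activity. No measurement is available here that explains this result.

Compound 1 differs from compound 2 and compound 3 in more than one place, so its gap from them cannot be assigned to its ring alone. From the compounds shown here alone, it remains open whether a plain phenyl ring, a saturated morpholine ring or a carboxylic acid at this position would fit the same picture.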